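From Benzyl to Isopropyl on the Ring Nitrogen

The source may report more compounds than this note shows. Statements on the series, on what has been measured and on what is new or still open speak of the compounds shown alone.

Compound 1 `Nc1ccccc1NC(=O)c1ccc(CNc2nc(Cl)nc3c2ncn3Cc2ccccc2)cc1` was tested in a functional assay on HCT-116 cells (Homo sapiens) for antiproliferative activity, read by CCK-8 assay, with a stated time of 72 h, tested at 2 uM (a lower number here means a weaker effect, a higher number a stronger effect of the compound at the concentration tested), and gives 7.7%, the lowest of the three numbers shown. Compound 2 `Nc1ccccc1NC(=O)c1ccc(Cn2cnc3c(NCc4ccccc4)nc(Cl)nc32)cc1` gives 68.3% in this assay, and compound 3 `Cc1ccc(Nc2nc(Cl)nc3c2ncn3Cc2ccc(C(=O)Nc3ccccc3N)cc2)cc1` gives 76.3%; both stand beyond the scatter above compound 1. Compound 4 `CC(C)n1cnc2c(NCc3ccc(C(=O)Nc4ccccc4N)cc3)nc(Cl)nc21` has not yet been measured. It differs from compound 1 in one place: isopropyl in place of benzyl on an aromatic nitrogen.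

Within the data shown here, only one measured step between single-change neighbours exists, a number 8 percentage points higher from compound 2 to compound 3 (within the scatter), and there the changed group sits on a nitrogen on an aromatic ring rather than on the aromatic nitrogen of the five-membered ring changed here; it also stays within the scatter. No measured step alters the group on that aromatic nitrogen, so nothing shown tells how isopropyl in place of benzyl acts at this position. The expectation therefore leans on compound 1 itself, and compound 4 is expected to remain close to it. The estimated step is a number 7.3 percentage points higher from compound 1 to compound 4 (within the scatter). Compound 4 is estimated to give 15% in this assay, within a range of 0% to 45%.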

Compound 4, a percentage reported as inhibition, at one concentration (the size of the read-out at that concentration, not a potency): 73.2%
Estimate against measurement, compound 4: 58.2 percentage points below; the whole stated range lies below it.
By their numbers in this assay, from the lowest: compound 1; then compounds 2, 4 and 3 (each within the scatter of the next).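

The group on the aromatic nitrogen of the five-membered ring matters greatly in this assay: isopropyl in place of benzyl gives a number 65.5 percentage points higher from compound 1 to compound 4 (beyond the scatter), the first measured change at this position and the only step shown that lies beyond the scatter. With the core of compound 1 otherwise unchanged, replacing a benzyl of 7 heavy atoms, with its six-membered aromatic ring, by an isopropyl of 3 heavy atoms and no ring goes with a large gain at the concentration tested. No measurement shown explains this gain.

This single pair does not separate the loss of the ring from the drop in size. Going by these compounds, how methyl, cyclopentyl or a longer chain such as butyl would act on the same nitrogen remains open.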